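The compounds below may be only part of what the source reports. "The series", "measured", "known", "first", "only" and "open" are said of these compounds alone.

Compound 1 `O=c1ccoc2cc(OCc3cn(Cc4cccc(Br)c4)nn3)ccc12` sits at the bottom of this small set. In a functional assay on MDA-MB-231 cells (Homo sapiens) for cytotoxicity, read by MTT assay, with a stated time of 48 h (on this read-out higher numbers stand for weaker inhibition and lower numbers for stronger inhibition), compound 1 gives only a limit of the assay, > 100000 nM. Compound 3 `O=c1ccoc2cc(OCc3cn(Cc4ccccc4Br)nn3)ccc12` also gives only a limit, > 100000 nM. Compound 2 `O=c1ccoc2cc(OCc3cn(Cc4ccccc4Cl)nn3)ccc12` gives a number, 15100 nM. Compound 4 `COc1ccc(Cn2cc(COc3ccc4c(=O)ccoc4c3)nn2)cc1` differs from compound 1 by 4-methoxyphenyl in place of 3-bromophenyl on a saturated chain carbon bound to an aromatic nitrogen. The steps that swap the aryl group on that same carbon are the nearest guides: an at least 6.6-fold lower number from compound 1 to compound 2 (0.82 log units; beyond the scatter), while a step that the two limits leave unreadable from compound 1 to compound 3. None of them carries a methoxy group, and since compound 1 stands at the limit of > 100000 nM in this assay, at which 2 of the 3 values shown sit, neither the size nor the direction of the new step can be read. The expected step is an at least 1.6-fold lower number from compound 1 to compound 4 (0.22 log units; that floor lies within the scatter). Compound 4 is therefore estimated at about 60000 nM, between 10000 nM and 200000 nM.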

Compound 4, half-maximal inhibitory concentration: > 100000 nM
Compound 4: a limit, no number; the forecaster's own chance of this, stated with the estimate: 55%; at least 1.6-fold (0.22 log units) between middle value and limit.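

In this assay, swapping the aryl group gives an at least 6.6-fold higher number from compound 2 to compound 4 (0.82 log units; beyond the scatter). Compound 4 thus shows that an aryl group without a halogen can also end at a limit, leaving compound 2 alone with a number. The steps to compound 4 from compound 1 and compound 3 cannot be read, because both ends of each are limits: the limit of > 100000 nM in this assay, at which 3 of the 4 values shown sit.

Going by these compounds, how far compound 1, compound 3 and compound 4 lie beyond that limit stays open. On these data alone, whether an amine or a carboxylic acid on the aryl group would give a number also stays open.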